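A few compounds are considered here, and "the series" means these few. Any claim that something is new, unique, unknown or untested is made for them only; others in the source may bear on it.

Compound 1 `CC(C)(C)c1ccc(C(=O)N2CCC3(CC2)C(=O)N(CC(=O)N2CCCC(C(N)=O)C2)CN3c2ccccc2)cc1` gives 16900 nM in an assay on HEK293 cells for displacement of a labelled ligand from NPC1-like intracellular cholesterol transporter 1 (Homo sapiens); a lower number here means a stronger inhibitor, a higher number a weaker inhibitor.
Compound 2 `CC1(C)CC(OC(=O)CN2CN(c3ccccc3)C3(CCN(C(=O)c4ccc(C(C)(C)C)cc4)CC3)C2=O)CC(C)(C)N1` gives 1300 nM in this assay.
Compound 3 `CC(C)(C)c1ccc(C(=O)N2CCC3(CC2)C(=O)N(CC(=O)N2CCC(O)CC2)CN3c2ccccc2)cc1` gives 4700 nM in this assay.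

Compound 3 stands second highest of the three numbers: the change from compound 1 to compound 3 gave a 3.6-fold lower number from compound 1 to compound 3 (0.56 log units; beyond the scatter), while the change from compound 2 to compound 3 gave a 3.6-fold higher number from compound 2 to compound 3 (0.56 log units; beyond the scatter). All three compounds share one core and differ only in the group attached at one carbonyl carbon.

Compound 4 `CC(C)(C)c1ccc(C(=O)N2CCC3(CC2)C(=O)N(CC(=O)N2CCN(S(C)(=O)=O)CC2)CN3c2ccccc2)cc1` is not yet measured. It differs from compound 3 in the same place: 4-(methylsulfonyl)piperazin-1-yl in place of 4-hydroxypiperidin-1-yl on a carbonyl carbon

Every measured step concerns that same carbonyl carbon, so all bear on this change. The step from compound 1 to compound 2 was a 13-fold lower number from compound 1 to compound 2 (1.11 log units; beyond the scatter), and the steps to compound 3 were modest. Yet the three groups are unlike the entering one, and no measured step swaps a 4-hydroxypiperidin-1-yl for a 4-(methylsulfonyl)piperazin-1-yl. The expectation for compound 4 is therefore a step of a 1.2-fold higher number from compound 3 to compound 4 (0.07 log units; within the scatter), within the scatter. Compound 4 is estimated at 5500 nM, with a range from 1500 nM to 18000 nM.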

Compound 4, half-maximal inhibitory concentration: 19000 nM
Compound 4: middle estimate off by 3.5-fold (0.54 log units), on the low side; measured number outside the range, above it.
By their numbers in this assay, from the lowest: compound 2; then compound 3; then compounds 1 and 4 (each within the scatter of the next).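

At this carbonyl carbon, exchanging one six-membered ring for another is not a neutral swap: 4-(methylsulfonyl)piperazin-1-yl in place of 4-hydroxypiperidin-1-yl gave a 4.0-fold higher number from compound 3 to compound 4 (0.61 log units; beyond the scatter), a clear loss of strength. The new group sits level with 3-carbamoylpiperidin-1-yl, with a 1.1-fold higher number from compound 1 to compound 4 (0.05 log units; within the scatter), and far from (2,2,6,6-tetramethylpiperidin-4-yl)oxy, with a 15-fold higher number from compound 2 to compound 4 (1.16 log units; beyond the scatter), so two differently built groups now share the weak end of this small set. Nothing measured here accounts for the loss.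

Compound 4 changes a ring carbon to nitrogen and adds the methylsulfonyl group in one move, so the compounds shown cannot say which of the two goes with the loss. An unsubstituted piperazine or a 4-acetylpiperazin-1-yl group at this carbonyl carbon would help to separate them.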